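A few compounds are considered here, and "the series" means these few. Any claim that something is new, unique, unknown or untested is made for them only; others in the source may bear on it.

Working notes on the series.

Three compounds have numbers in an assay on isolated protein for inhibition of Leucine-rich repeat serine/threonine-protein kinase 2 (Homo sapiens), read by TR-FRET and LanthaScreen, with stated times of 50 min and 30 min, in the presence of a further agent that is not named here; a higher number here means a weaker inhibitor, a lower number a stronger inhibitor. Compound 1 `Cc1c(Nc2nc(N)c3c(C#N)c(N4CCC[C@H]4C)n(C)c3n2)cnn1CC(C)(C)O` gives 43 nM. Compound 2 `CN(C)c1c(C#N)c2c(N)ncnc2n1C`, which lacks the amino-linked pyrazole of the others, gives 4620 nM. Compound 3 `C[C@@H]1CCCN1c1c(C#N)c2c(N)nc(Nc3cn(C)nc3Cl)nc2n1C` gives 34 nM in this assay, the lowest of the three numbers; compound 1 sits within the usual scatter of it, while compound 2 lies far beyond it.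

The next step goes to compound 4 `C[C@@H]1CCCN1c1c(C#N)c2c(N)nc(Nc3cn[nH]c3)nc2n1C`, which differs from compound 3 in one place: 1H-pyrazol-4-yl in place of 3-chloro-1-methyl-1H-pyrazol-4-yl on a nitrogen on an aromatic ring. The chlorine and the ring methyl are lost and an amide-like ring hydrogen appears on the pyrazole.

For the measured compounds named here, no measured pair shows this exact change. Compound 1 carries a pyrazole with other substituents and returns 43 nM, so the series tolerates variation at this ring. A small shift toward a higher number is expected, likely within or at the edge of the scatter; the expected step of a 2.6-fold higher number from compound 3 to compound 4 (0.42 log units; beyond the scatter) is modest. Compound 4 is estimated at 90 nM, with a range from 30 nM to 300 nM.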

Compound 4, half-maximal inhibitory concentration: 6 nM
Beside the measured number, compound 4's estimate is 15-fold (1.18 log units) above it; the measured number lies below the stated range.
By their numbers in this assay, from the lowest: compound 4; then compounds 3 and 1 (each within the scatter of the next); then compound 2.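

In this assay, 1H-pyrazol-4-yl in place of 3-chloro-1-methyl-1H-pyrazol-4-yl on a nitrogen on an aromatic ring gives a 5.7-fold lower number from compound 3 to compound 4 (0.75 log units; beyond the scatter). For the compounds shown here, this is the first single-place comparison at this position, and it shows that neither the chlorine nor the ring methyl is required for a low number in this pair, while the entering group carries 1 hydrogen-bond donor where the leaving group carries 0. No supporting measurement accounts for the step.

As far as these compounds go, the chlorine and the ring methyl leave together, so the share of the step belonging to each remains open. Also open, from the compounds shown here alone, is how the number responds when the ring hydrogen of compound 4 is replaced by a longer chain, an amine or a carboxylic acid.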